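Moving a Methoxy Group on a Benzyl Ether

The source may hold more compounds than are shown below. What is called first, only, known or untested is meant among the compounds shown, and "the series" means these compounds.

Measured so far:
- compound 1, `COc1cccc(OC)c1OCCNCCOc1ccccc1OCc1ccccc1`: 8.3
- compound 2, `COc1ccccc1COc1ccccc1OCCNCCOc1c(OC)cccc1OC`: 8.13
- compound 3, `COc1cccc(COc2ccccc2OCCNCCOc2c(OC)cccc2OC)c1`: not yet measured

Both measured compounds were tested in a functional assay on spleen for antagonist activity at Alpha-1B adrenergic receptor (Rattus norvegicus); on this read-out higher numbers stand for higher potency (the scale is a negative logarithm) and lower numbers for lower potency. Compound 1 and compound 2 differ only by a methoxy in place of hydrogen on an aromatic carbon, and the step of a number 0.17 log units lower from compound 1 to compound 2 (within the scatter) falls within the usual scatter of repeated measurements, so compound 2 stands alongside compound 1 rather than apart from it.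

Compound 3 keeps every atom of compound 2 and changes only the connection: 3-methoxyphenyl in place of 2-methoxyphenyl on a saturated chain carbon bound to an oxygen on an aromatic ring. Among the measured compounds shown here, no measured step covers a change of this kind. For the measured compounds named here, the single known step, from adding a methoxy group to an aromatic carbon, was small and says nothing about shifting a methoxy group from one place on a benzyl ring to another. Going by the values given here, with no precedent either way, the expectation for compound 3 in this assay is a step of a number 0.13 log units lower from compound 2 to compound 3 (within the scatter), not beyond the scatter. The estimate for compound 3 is 8, with a likely range from 7.4 to 8.6.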

Compound 3, negative logarithm of the antagonist equilibrium constant: 8.31
For compound 3 the middle estimate is 0.31 log units below the measured one; the measured number falls inside the stated range.
By their numbers in this assay, from the lowest: compounds 2, 1 and 3 (each within the scatter of the next).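

In this assay, among the compounds shown here, shifting the group from 2-methoxyphenyl to 3-methoxyphenyl on a saturated chain carbon bound to an oxygen on an aromatic ring gives a number 0.18 log units higher from compound 2 to compound 3 (within the scatter) and so keeps the same atoms with no step that can be told apart from repeat-measurement noise. Adding a methoxy group to the unsubstituted benzyl ring of compound 1 now has a second reading, a number 0.01 log units higher from compound 1 to compound 3 (within the scatter) and, like the first, it stays inside the scatter, so compound 1, compound 2 and compound 3 stand level and this part of the molecule accepts a methoxy group at either of the two tested places without a clear change in this read-out. No accompanying data offer an explanation for why these numbers stay together.

What the three compounds leave open is whether this tolerance is special to methoxy or would also hold for a different group on the benzyl ring, such as a hydroxy group, a chlorine atom or a carboxylic acid. They also leave open whether the same level picture would hold at any other receptor, since all three numbers come from a single assay.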